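Series notes: from compound 2 to compound 4

The source may report more compounds than this note shows. Statements on the series, on what has been measured and on what is new or still open speak of the compounds shown alone.

Among the compounds with values here, compound 2 `O=C1CCCN1c1cnc(NCc2c(F)ccc3c2CCO3)n2cnnc12` gives 1.3 in a physicochemical assay for lipophilicity, using the shake flask method, in phosphate buffer, measured as octanol-water partition, with a stated time of 30 min, at pH 7.4 (on this read-out higher numbers stand for higher lipophilicity and lower numbers for lower lipophilicity), the lowest of the three numbers so far. Compound 3 `O=C1CCCN1c1cnc(NCc2c(F)ccc3c2CCO3)c2cn[nH]c(=O)c12` gives 1.8 and compound 1 `Cn1cc(-c2cnc(NCc3c(F)ccc4c3CCO4)c3cn[nH]c(=O)c23)cn1` gives 2.7; both gaps to compound 2 lie beyond the scatter. Compound 4 `O=C(Nc1cnc(NCc2c(F)ccc3c2CCO3)n2cnnc12)c1ccccc1` is not yet measured and differs from compound 2 by benzamido in place of 2-oxopyrrolidin-1-yl on an aromatic carbon. Within the data shown here, the one measured single-point step, a number 0.90 log units lower from compound 1 to compound 3 (beyond the scatter), concerns a different exchange at the same kind of position and offers no direct guide for a benzamido group, which no measured compound carries. A clear rise in this assay is nevertheless expected. Compound 4 is estimated at 2.3, with a range from 1.6 to 3. The step of a number 1.00 log units higher from compound 2 to compound 4 (beyond the scatter) is expected to lie beyond the scatter.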

Compound 4, distribution coefficient: 3
Compound 4: the middle estimate sits 0.70 log units below what was measured, within the range that was stated.
By their numbers in this assay, from the lowest: compound 2; then compound 3; then compounds 1 and 4 (each within the scatter of the next).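

At this aromatic carbon, on the shared core, the number in this assay is highly sensitive to the group attached: a number 1.70 log units higher from compound 2 to compound 4 (beyond the scatter), a larger step than any seen before. The entering benzamido brings a six-membered aromatic ring of carbon only and 1 hydrogen-bond donor, and this single exchange cannot separate the two. No measurement here accounts for the rise.

Open, as far as these compounds go, is whether an acetamido group or a plain amine at this carbon gives a similar number. Also open, from the compounds shown here alone, is whether benzamido gives a step of similar size on the core of compound 3.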